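Adding a Second Chloro to a Benzyl Purine

A few compounds are considered here, and "the series" means these few. Any claim that something is new, unique, unknown or untested is made for them only; others in the source may bear on it.

Measured compounds:
compound 1, `CN(C)c1ncnc2c1ncn2Cc1ccc(Cl)cc1`, 0%
compound 2, `CN(C)c1ncnc2c1ncn2Cc1ccc(F)cc1`, 33%

Among the measured compounds shown here, compound 1, `CN(C)c1ncnc2c1ncn2Cc1ccc(Cl)cc1`, shows no effect in a functional assay on the whole organism for inhibition, with Rattus norvegicus as the target, in the maximal electroshock model, at a dose of 25 mg/kg by the intraperitoneal route; on this read-out higher numbers stand for more inhibition at the one dose given (going by the name of the read-out) and lower numbers for less inhibition: compound 1 gives 0%, the lowest of the two numbers known. Compound 2, `CN(C)c1ncnc2c1ncn2Cc1ccc(F)cc1`, gives 33% in this assay, and the step of a number 33 percentage points higher from compound 1 to compound 2 (beyond the scatter) came with fluoro in place of chloro on an aromatic carbon.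

Compound 3, `CN(C)c1ncnc2c1ncn2Cc1ccc(Cl)c(Cl)c1`, differs from compound 1 by chloro in place of hydrogen on an aromatic carbon. For the measured compounds named here, no measured step involves chloro entering where a hydrogen was, so the one known step, which swapped a halogen for another, does not bear directly on this change. With nothing to point either way, the expected step from compound 1 to compound 3 in this assay is a number 10 percentage points higher from compound 1 to compound 3 (within the scatter), within the scatter. Compound 3 is therefore estimated at 10%, in the range 0% to 35%.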

Compound 3, a percentage reported as inhibition, in the whole organism at one dose (the size of the read-out at that dose, not a potency): 0%
Estimate against measurement, compound 3: 10 percentage points above; measured number inside the range.
By their numbers in this assay, from the lowest: compounds 1 and 3 (each within the scatter of the next); then compound 2.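

Chloro in place of hydrogen, ortho to the chloro group already present, gives no change at the digits printed from compound 1 to compound 3 (within the scatter) in this assay and is the first step here in which a group enters where a hydrogen stood, rather than one halogen replacing another. Compound 1 already stands at 0% so the read-out has no room to show a loss: the extra chloro adds no measurable inhibition at the one dose given, but any harm it might do stays hidden. Nothing measured on these compounds explains the result.

From the compounds shown here alone, whether another group at this position, such as an amine or a methoxy group, would raise the number remains open. So does whether the added chloro would act the same way on compound 2, where a fall could show.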